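Ring Size at the Amide: Cyclobutyl to Cyclopentyl

A few compounds are considered here, and "the series" means these few. Any claim that something is new, unique, unknown or untested is made for them only; others in the source may bear on it.

Compound 1 `CCCC(C)C(=O)Nc1c(C(O)(C(F)(F)F)C(F)(F)F)ccc2ccccc12`: > 10000 nM
Compound 2 `O=C(Nc1c(C(O)(C(F)(F)F)C(F)(F)F)ccc2ccccc12)C1CCC1`: 45 nM

In an assay on LtK cells with ATP-sensitive inward rectifier potassium channel 11 (Homo sapiens) as the target (a lower number here means that less compound is needed, a higher number that more compound is needed for the effect), compound 1 gives > 10000 nM, which is a limit of the assay and not a number; it sits at the limit of > 10000 nM in this assay, at which 1 of the 2 values shown sits. For the measured compounds named here, compound 2 gives 45 nM, the only real number here. The step of an at least 220-fold lower number from compound 1 to compound 2 (2.34 log units; beyond the scatter) is large. Compound 3 `O=C(Nc1c(C(O)(C(F)(F)F)C(F)(F)F)ccc2ccccc12)C1CCCC1` differs from compound 2 by cyclopentyl in place of cyclobutyl on a carbonyl carbon. Going by the values given here, only that one step bears on this change, and it involved an open-chain group rather than a ring, so it offers little guidance for a modest ring enlargement. A step of a 1.3-fold higher number from compound 2 to compound 3 (0.12 log units; within the scatter) is expected. Compound 3 is estimated at 60 nM, between 15 nM and 300 nM.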

Compound 3, half-maximal effective concentration: 495 nM
Compound 3: middle estimate off by 8.3-fold (0.92 log units), on the low side; the whole stated range lies below it.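

In this assay the position on the carbonyl carbon turns out to be sensitive to ring size alone: cyclopentyl in place of cyclobutyl gives an 11-fold higher number from compound 2 to compound 3 (1.04 log units; beyond the scatter) even though both groups are small carbon rings. Cyclopentyl still compares well with the open-chain 1-methylbutyl group, with an at least 20-fold lower number from compound 1 to compound 3 (1.30 log units; beyond the scatter) as the step between them. The value of compound 1 is a limit of the assay and not a number: the limit of > 10000 nM in this assay, at which 1 of the 3 values shown sits.

From the compounds shown here alone, two ring sizes do not make a trend, so cyclopropyl and cyclohexyl remain open. So does a ring containing oxygen, such as tetrahydrofuranyl, or a shorter branched chain, such as isopropyl.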